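The source may hold more compounds than are shown below. What is called first, only, known or untested is meant among the compounds shown, and "the series" means these compounds.

The measured compounds so far:

Compound 1, `O=[N+]([O-])c1cn2c(n1)OC[C@@H](OCc1ccc(-c3ccc(OC(F)(F)F)cc3)cc1)C2`, gives > 128000 nM in an ADME assay on Vero cells (Chlorocebus sabaeus) for cytotoxicity, with a stated time of 72 h; on this read-out lower numbers stand for stronger inhibition and higher numbers for weaker inhibition; this value is a limit of the assay, not a number.
Compound 2, `N#Cc1ccc(-c2cccc(CO[C@@H]3COc4nc([N+](=O)[O-])cn4C3)c2)cc1`, gives > 128000 nM in this assay; this too is a limit, not a number.

Compound 2 therefore stands where compound 1 stands: both readings sit at the same limit, as the limit of > 128000 nM in this assay, at which 2 of the 2 values shown sit, records, and neither gives a number that could set one apart from the other. Among the compounds with values here, no step between the two measured compounds is counted here, so their readings show only that both lie at the limit.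

Compound 3, `O=[N+]([O-])c1cn2c(n1)OC[C@@H](OCc1cccc(-c3ccc(OC(F)(F)F)cc3)c1)C2`, has not yet been measured in this assay. It differs from compound 2 in one place, (trifluoromethoxy in place of cyano on an aromatic carbon), that is, trifluoromethoxy in place of cyano on an aromatic carbon. Because both readings shown sit at the limit described in the limit of > 128000 nM in this assay, at which 2 of the 2 values shown sit, the step from compound 2 to compound 3 is expected to be none beyond the scatter, and the reading for compound 3 is expected most likely to be a limit again. The estimate for compound 3 is 150000 nM, within the range 60000 nM to 400000 nM, corresponding to an expected step that the limit leaves unreadable from compound 2 to compound 3.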

Compound 3, half-maximal inhibitory concentration: > 128000 nM
Compound 3: a limit, no number (the forecaster's own chance of this, stated with the estimate: 85%); the middle value lies beyond the limit too.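

Compound 2 and compound 3 both read as limits, not numbers, in this assay, so no step can be read between them, and the effect of trifluoromethoxy in place of cyano cannot be sized. The compounds shown leave open how far their cytotoxicity readings lie from one another, as all of them share one reading: the limit of > 128000 nM in this assay, at which 3 of the 3 values shown sit.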